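The source may report more compounds than this note shows. Statements on the series, on what has been measured and on what is new or still open speak of the compounds shown alone.

Measured compounds:
Compound 1, `CC1CCCCN1C(=S)SCc1ccc(C(=O)Nc2ccccc2N)cc1`, gives 86.9% in a functional assay on MGC-803 cells (Homo sapiens) for antiproliferative activity, read by CCK-8 assay, with a stated time of 72 h, tested at 8 uM; a higher number here means a stronger effect of the compound at the concentration tested, a lower number a weaker effect.
Compound 2, `Nc1ccccc1NC(=O)c1ccc(CSC(=S)N2CCCc3ccccc32)cc1`, gives 87.5% in this assay.
Compound 3, `Nc1ccccc1NC(=O)c1ccc(CSC(=S)N2CCN(c3ccncc3)CC2)cc1`, gives 87.1% in this assay.

Compound 3 stands second highest of these three numbers, with compound 1 nearest and compound 2 furthest, yet all three lie within the scatter of one another, so no order among them can be read. Compound 4, `Nc1ccccc1NC(=O)c1ccc(CSC(=S)N2CCN(Cc3cccnc3)CC2)cc1`, has not yet been tested. It differs from compound 3 in one place: (pyridin-3-yl)methyl in place of pyridin-4-yl on an amine nitrogen in a ring. Going by the values given here, the only measured step, a number 0.6 percentage points higher from compound 1 to compound 2 (within the scatter), concerns the group on the thiocarbonyl carbon rather than the amine nitrogen in the ring that is changed here, so it does not bear directly on the step to compound 4; it shows only that exchanging a ring substituent on this shared core left this assay unmoved. Compound 3 and compound 1 differ in more than one place, and their two values are likewise within the scatter of each other. With no step beyond the scatter anywhere in the set, the step of a number 1.1 percentage points lower from compound 3 to compound 4 (within the scatter) is expected to stay within the scatter as well. Compound 4 is therefore estimated to give 86% in this assay, within a range from 72% to 94%.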

Compound 4, a percentage reported as inhibition, at one concentration (the size of the read-out at that concentration, not a potency): 64.6%
Beside the measured number, compound 4's estimate is 21.4 percentage points above it; the measured number lies below the stated range.
By their numbers in this assay, from the lowest: compound 4; then compounds 1, 3 and 2 (each within the scatter of the next).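

In this assay, going by these compounds alone, the group on the amine nitrogen in the ring proved to matter: (pyridin-3-yl)methyl in place of pyridin-4-yl brought a number 22.5 percentage points lower from compound 3 to compound 4 (beyond the scatter), the only step in the set beyond the scatter, whereas the earlier step at the thiocarbonyl carbon, a number 0.6 percentage points higher from compound 1 to compound 2 (within the scatter), stayed within it. The two groups have the same counts of hydrogen-bond donors and acceptors and the same net charge, so those counts do not separate them; what differs is the methyl link in the entering group and the point at which the pyridine ring is attached. Nothing available here explains the lower number at this position.

The step joins those two differences, and the compounds shown do not tell them apart, which pyridin-3-yl or (pyridin-4-yl)methyl on the same nitrogen could do. Also open, from the compounds shown here alone, is whether the ring nitrogen matters at all, which a benzyl group could address, and how a longer chain such as 2-(pyridin-3-yl)ethyl would read in this assay.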